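Stability notes on a sulfonamide-oxadiazole series

A few compounds are considered here, and "the series" means these few. Any claim that something is new, unique, unknown or untested is made for them only; others in the source may bear on it.

Measured so far in an ADME assay on microsomes from liver (Homo sapiens) for metabolic stability, read by LC-MS, using NADPH, tested at 5 uM; on this read-out lower numbers stand for a shorter-lived compound and higher numbers for a longer-lived compound:
- compound 1 `NS(=O)(=O)c1cc(-c2nnc(CN3CCN(c4ccccc4)CC3)o2)c(Cl)cc1SCc1ccccc1` gives 0.33 h
- compound 2 `NS(=O)(=O)c1cc(-c2nnc(Cn3cc(-c4ccccc4)nn3)o2)c(Cl)cc1SCc1ccccc1` gives 0.21 h

For the measured compounds named here, compound 2 holds the lowest of the two numbers in this assay, with compound 1 as its nearest neighbour; the single step, a 1.6-fold lower number from compound 1 to compound 2 (0.20 log units; within the scatter), lies within the scatter, so the two compounds are not separable on this read-out.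

Compound 3 `NS(=O)(=O)c1cc(-c2nnc(/C=C/c3cccc(Cl)c3)o2)c(Cl)cc1SCc1ccccc1` is not yet measured. It differs from compound 2 by 2-(3-chlorophenyl)ethenyl in place of (4-phenyl-1H-1,2,3-triazol-1-yl)methyl on an aromatic carbon. Going by the values given here, no measured step alters this position of the shared core in a comparable way; the only step available, from compound 1 to compound 2, exchanged one group for another on the saturated chain carbon and stayed within the scatter. The data therefore give no ground to expect a step beyond the scatter in this assay, in either direction.

Compound 3 is accordingly estimated at 0.25 h, within 0.1 h to 0.6 h, an expected step of a 1.2-fold higher number from compound 2 to compound 3 (0.08 log units; within the scatter).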

Compound 3, half-life: 0.352 h
Compound 3: middle estimate off by 1.4-fold (0.15 log units), on the low side; measured number inside the range.
By their numbers in this assay, from the lowest: compounds 2, 1 and 3 (each within the scatter of the next).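

In this assay, replacing (4-phenyl-1H-1,2,3-triazol-1-yl)methyl with 2-(3-chlorophenyl)ethenyl on this aromatic carbon gives a 1.7-fold higher number from compound 2 to compound 3 (0.22 log units; within the scatter), so an exchange of the whole group at this position still leaves the compounds unseparated, whereas the earlier step altered only the group on the saturated chain carbon. The entering group has no five-membered aromatic ring and none of the 3 hydrogen-bond acceptors of the leaving group, yet neither difference is tied to a step beyond the scatter. No supporting measurement bears on this result.

On these data alone, whether any group at this position can give a step beyond the scatter remains open. A carboxylic acid, a morpholine ring or a longer chain in place of the ethenyl link would test this.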